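The source may report more compounds than this note shows. Statements on the series, on what has been measured and on what is new or still open speak of the compounds shown alone.

Compound 1 `O=S(=O)(CC1=NCCO1)C1C(c2ccc(Cl)cc2)=NOC1c1ccc(Cl)cc1` belongs to a small set of compounds in which a sulfonyl group links a substituted isoxazoline core to a short chain carrying a five-membered ring. In a functional assay, read by Griess assay, with a stated time of 150 min, tested at 50 ug/mL (a lower number here means a weaker effect, a higher number a stronger effect of the compound at the concentration tested), compound 1 gave "not active" (no number reported), so no number stands for it. Compound 2 `COc1ccc(C2=NOC(c3ccc(C)cc3)C2S(=O)(=O)CC2=NCCO2)cc1` has a different core, and the difference between the two cores is not broken down here. In this assay compound 2 gives 61.9%. Compound 3 `COc1ccc(C2=NOC(c3ccc(C)cc3)C2S(=O)(=O)CC2=NCCS2)cc1` shares the core of compound 2 and differs from it only in one place: a group of 5 heavy atoms (3 carbon, 1 nitrogen, 1 sulfur; one five-membered non-aromatic ring with 2 hetero atoms) in place of a group of 5 heavy atoms (3 carbon, 1 nitrogen, 1 oxygen; one five-membered non-aromatic ring with 2 hetero atoms), on a saturated chain carbon bound to a sulfonyl sulfur. In this assay compound 3 gives 48.6%. This change made a modest step, a number 13.3 percentage points lower from compound 2 to compound 3 (beyond the scatter), which lies beyond the usual scatter of the measurement.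

Compound 4 `O=S(=O)(CC1=NCCS1)C1C(c2ccc(Cl)cc2)=NOC1c1ccc(Cl)cc1` is not yet measured. It stands to compound 1 as compound 3 stands to compound 2: a group of 5 heavy atoms (3 carbon, 1 nitrogen, 1 sulfur; one five-membered non-aromatic ring with 2 hetero atoms) in place of a group of 5 heavy atoms (3 carbon, 1 nitrogen, 1 oxygen; one five-membered non-aromatic ring with 2 hetero atoms), on a saturated chain carbon bound to a sulfonyl sulfur. The two "place" descriptions agree word for word, so this is the same change on a different core. From compound 1 to compound 4 the step in this assay cannot be told as a number, since compound 1 itself has none. Within the data shown here, the one measured instance of this change, the step from compound 2 to compound 3, went downward, and compound 1 already gave no measurable effect. Compound 4 is therefore expected to give about 8%, most likely reported again as not active, with a range estimated between 0% and 25%.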

Compound 4, a percentage reported as activity, at one concentration (the size of the read-out at that concentration, not a potency): "not active" (no number reported)
The entry for compound 4 holds no number, and the estimate cannot be compared.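

In this assay compound 1 gives "not active" (no number reported) and compound 4 gives "not active" (no number reported) and so no new step can be read between these two compounds. Nothing shown here offers an explanation for this result. Left open is whether the ring change that lowered the number from compound 2 to compound 3 has any effect on the core shared by compound 1 and compound 4.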